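Shrinking the sulfonyl group further in a Bcl-2 series

The source may hold more compounds than are shown below. What is called first, only, known or untested is meant among the compounds shown, and "the series" means these compounds.

Of the compounds shown here, three sharing one core have been measured in an assay on isolated protein for inhibition of Apoptosis regulator Bcl-2/Bcl-2 homologous antagonist/killer (Homo sapiens), read by surface plasmon resonance, with a stated time of 1 h; on this read-out lower numbers stand for an effect already at smaller amounts and higher numbers for an effect only at larger amounts of compound. Compound 1 `CC1(C)[C@@]2(C)CC[C@H](CS(=O)(=O)NC(=O)c3ccc(N4CCN(Cc5ccccc5-c5ccc(Cl)cc5)CC4)cc3)[C@]1(C)C2` gives 560 nM. Compound 2 `CC1(C)C2CC[C@@]1(CS(=O)(=O)NC(=O)c1ccc(N3CCN(Cc4ccccc4-c4ccc(Cl)cc4)CC3)cc1)C(=O)C2` gives 1470 nM, and a 2.6-fold higher number from compound 1 to compound 2 (0.42 log units; beyond the scatter). Compound 3 `CC(C)(C)S(=O)(=O)NC(=O)c1ccc(N2CCN(Cc3ccccc3-c3ccc(Cl)cc3)CC2)cc1` reaches only the limit of the assay, > 16000 nM, so no number is known for it. Both steps toward compound 3 run the same way: an at least 28-fold higher number from compound 1 to compound 3 (1.45 log units; beyond the scatter), and an at least 10-fold higher number from compound 2 to compound 3 (1.03 log units; beyond the scatter). Each time a smaller group on the sulfonyl sulfur went with a higher number. Compound 3 thus stands at the limit of > 16000 nM in this assay, at which 1 of the 3 values shown sits.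

Compound 4 `CS(=O)(=O)NC(=O)c1ccc(N2CCN(Cc3ccccc3-c3ccc(Cl)cc3)CC2)cc1` is not yet measured. It differs from compound 3 in one place: methyl in place of tert-butyl on a sulfonyl sulfur. This cuts the group on the sulfonyl sulfur down once more. On the strength of an at least 28-fold higher number from compound 1 to compound 3 (1.45 log units; beyond the scatter) and an at least 10-fold higher number from compound 2 to compound 3 (1.03 log units; beyond the scatter), compound 4 is expected to show no smaller a number in this assay than compound 3, and most likely to sit at the limit again. The estimate for compound 4 is 30000 nM, within 12000 nM to 100000 nM. The expected step is a step that the limit leaves unreadable from compound 3 to compound 4, with the limit making a true number unlikely.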

Compound 4, half-maximal effective concentration: 8620 nM
Beside the measured number, compound 4's estimate is 3.5-fold (0.54 log units) above it; the measured number lies below the stated range.
By their numbers in this assay, from the lowest: compound 1; then compound 2; then compound 4. At a limit, above all of these: compound 3.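

Methyl in place of tert-butyl on a sulfonyl sulfur gives an at least 1.8-fold lower number from compound 3 to compound 4 (0.26 log units; that floor lies within the scatter) and so compound 4 goes against the earlier run, in which a smaller group went with a higher number. Against the two ring-bearing groups the earlier direction still holds: a 5.9-fold higher number from compound 2 to compound 4 (0.77 log units; beyond the scatter) stands alongside a 15-fold higher number from compound 1 to compound 4 (1.19 log units; beyond the scatter) in this series. Compound 3 itself has only a limit and no number: the limit of > 16000 nM in this assay, at which 1 of the 4 values shown sits.

The compounds shown leave open where an ethyl group, a longer chain such as n-butyl or a phenyl ring on the sulfonyl sulfur would fall relative to methyl and the ring-bearing groups. They also leave open the true number of compound 3, and with it how far methyl and tert-butyl really differ.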